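A few compounds are considered here, and "the series" means these few. Any claim that something is new, unique, unknown or untested is made for them only; others in the source may bear on it.

In an assay on CHO cells for displacement of a labelled ligand from corticotropin-releasing factor receptor 1 (Homo sapiens) (on this read-out lower numbers stand for stronger inhibition and higher numbers for weaker inhibition), compound 1 `CCCN(c1nccc(-c2c(OC)cc(OC)cc2OC)n1)C(C1CC1)C1CC1` gives 15 nM. Compound 2 `CCCN(c1nccc(-c2c(OC)cc(OC)cc2OC)n1)C1(c2ccoc2)CC1` gives 700 nM, and compound 3 `CCCN(c1nccc(-c2ccc(OC)cc2OC)n1)C(C1CC1)C1CC1` gives 460 nM; compound 3 thus stands second highest of the three numbers, close to compound 2 and far from compound 1. The two measured steps are a 47-fold higher number from compound 1 to compound 2 (1.67 log units; beyond the scatter) and a 31-fold higher number from compound 1 to compound 3 (1.49 log units; beyond the scatter). Compound 4 `CCCN(c1ncc(C)c(-c2ccc(OC)cc2OC)n1)C(C1CC1)C1CC1` differs from compound 3 by methyl in place of hydrogen on an aromatic carbon. Neither measured step touches this place on the shared core, so the data give no guide to how such a methyl acts, and no shift beyond the scatter is expected in this assay. Compound 4 is therefore estimated at 460 nM, likely between 150 nM and 1400 nM, which means an expected step of no change at the digits printed from compound 3 to compound 4 (within the scatter).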

Compound 4, inhibition constant: 19 nM
Beside the measured number, compound 4's estimate is 24-fold (1.38 log units) above it; the measured number lies below the stated range.
By their numbers in this assay, from the lowest: compounds 1 and 4 (each within the scatter of the next); then compounds 3 and 2 (each within the scatter of the next).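

In this assay, one methyl in place of hydrogen on an aromatic carbon of the six-membered ring with 2 nitrogen gives a large shift toward stronger inhibition (a 24-fold lower number from compound 3 to compound 4 (1.38 log units; beyond the scatter)). Going by these compounds alone, this position, which no earlier step touched, therefore responds strongly to the addition of a single heavy atom. No available evidence accounts for this shift. Still open, as far as these compounds go, is whether an ethyl group, a chlorine atom or an amine at this position would act like methyl. Also open, from the compounds shown here alone, is whether methyl would give a similar shift on compound 1.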